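Replacing 4-Bromophenyl with Pyridin-3-yl: Expected Clearance of Compound 3

This account rests on a few compounds, and the source may have more. Where it says the series, first, only, none or still open, it means among the compounds named here.

Compound 1, `CCOC(=O)C1=C(C)N/C(=C/c2cc(C)n(-c3ccc(Br)cc3)c2C)C1=O`, gives 62 mL.min-1.g-1 in an ADME assay on microsomes from liver (Mus musculus) for metabolic stability, read by LC-MS, tested at 1 uM; a lower number here means slower removal, a higher number faster removal of the compound.
Compound 2, `CCOC(=O)C1=C(C)N/C(=C/c2cc(C)n(-c3ccc(S(=O)(=O)C(F)(F)F)cc3)c2C)C1=O`, gives 58 mL.min-1.g-1.

Going by the values given here, of the two numbers so far, compound 1 carries the higher one, yet compound 2 lies only a 1.1-fold lower number from compound 1 to compound 2 (0.03 log units; within the scatter) away, so the two cannot be told apart. Compound 3, `CCOC(=O)C1=C(C)N/C(=C/c2cc(C)n(-c3cccnc3)c2C)C1=O`, is the next compound to be measured. It differs from compound 1 in one place: pyridin-3-yl in place of 4-bromophenyl on an aromatic nitrogen. Among the compounds with values here, the only measured step that bears on this change is a 1.1-fold lower number from compound 1 to compound 2 (0.03 log units; within the scatter), which stayed within the scatter. Within the data shown here, no measured step exchanges the whole six-membered ring, so the expectation rests on that single step. Compound 3 is therefore expected to show no change beyond the scatter, a step of about a 1.2-fold lower number from compound 1 to compound 3 (0.09 log units; within the scatter). The estimate for compound 3 is 50 mL.min-1.g-1, with a range from 25 mL.min-1.g-1 to 100 mL.min-1.g-1.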

Compound 3, intrinsic clearance in microsomes: 82 mL.min-1.g-1
Compound 3: middle estimate off by 1.6-fold (0.21 log units), on the low side; low and high end bracket the measured number.
By their numbers in this assay, from the lowest: compounds 2, 1 and 3 (each within the scatter of the next).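

Exchanging the whole ring on the aromatic nitrogen, and not only a group on that ring, gives a 1.3-fold higher number from compound 1 to compound 3 (0.12 log units; within the scatter) in this assay. The earlier step from compound 1 to compound 2 kept the carbon-only ring and altered only the group on it, whereas pyridin-3-yl brings a ring nitrogen and a hydrogen-bond acceptor into this place. Even so, the number for compound 3 cannot be told apart from that for compound 1, and nothing measured here bears on what sets clearance at this position.

Going by these compounds, all three compounds carry a six-membered aromatic ring on this nitrogen, so it remains open whether a plain alkyl chain there would give a step beyond the scatter. The same question stands for a carboxylic acid or an amine on the ring.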